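The source may report more compounds than this note shows. Statements on the series, on what has been measured and on what is new or still open speak of the compounds shown alone.

Among the measured compounds shown here, the three compounds measured so far share one assay, a functional assay on a cell-free system (plasma, Homo sapiens), with a stated time of 3 min (a lower number here means a stronger inhibitor, a higher number a weaker inhibitor), and all land close together. Compound 1 `O=C(NCc1cc(Cl)ccc1-n1cnnn1)[C@@H]1C[C@@H]2C[C@@H]2N1C(=O)[C@H](O)c1cccc(Cl)c1` gives 1000 nM. Compound 2 `Cc1cccc([C@@H](O)C(=O)N2N=CC[C@H]2C(=O)NCc2cc(Cl)ccc2-n2cnnn2)c1` gives 830 nM. Compound 3 `O=C(NCc1cc(Cl)ccc1-n1cnnn1)[C@@H]1C[C@H]2C[C@H]2N1C(=O)[C@H](O)CC1CC1` gives 850 nM. Compound 2 shows the lowest of the three numbers, but its gaps to compound 3 and to compound 1 both fall within the usual scatter, so no order among them can be read from these values.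

Compound 4 `CC(C)(C)OC[C@@H](O)C(=O)N1N=CC[C@H]1C(=O)NCc1cc(Cl)ccc1-n1cnnn1` has not yet been measured. It differs from compound 2 in one place: (tert-butoxy)methyl in place of 3-methylphenyl on a saturated chain carbon bound to a carbonyl carbon and an oxygen on a saturated carbon.

For the measured compounds named here, no step between measured compounds shows the effect of such a change directly. What the numbers do show is that compound 1 and compound 3, which carry an aromatic and a non-aromatic group at the corresponding place on a related core, give values that sit within the scatter of each other. On that basis a step from compound 2 to compound 4 of about a 1.2-fold higher number from compound 2 to compound 4 (0.08 log units; within the scatter) is expected, not beyond the scatter in either direction. Compound 4 is therefore estimated at 1000 nM in this assay, with a range from 300 nM to 3500 nM.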

Compound 4, half-maximal inhibitory concentration: 750 nM
For compound 4 the middle estimate is 1.3-fold (0.12 log units) above the measured one; measured number inside the range.
By their numbers in this assay, from the lowest: compounds 4, 2, 3 and 1 (each within the scatter of the next).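

In this assay, putting (tert-butoxy)methyl in place of 3-methylphenyl on the same core gives a 1.1-fold lower number from compound 2 to compound 4 (0.04 log units; within the scatter). Among the compounds shown here, this is the first direct comparison at this position, and it shows that, for this pair, a group with no ring and one hydrogen-bond acceptor gives a number that cannot be told apart from that of the six-membered aromatic ring. No measurement shown here offers an explanation for this result.

The compounds shown leave open whether an amine or a carboxylic acid at this place would give a number beyond the scatter. They also leave open whether the same exchange would give a step of similar size on the core of compound 1 or the core of compound 3.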